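Methyl on the Phenol Oxygen and Ehrlich Cell Cytotoxicity

The source may report more compounds than this note shows. Statements on the series, on what has been measured and on what is new or still open speak of the compounds shown alone.

In a functional assay on Ehrlich cells (Mus musculus) for cytotoxicity, read by trypan blue exclusion, with a stated time of 2 h, tested at 100 ug/mL (a higher number here means a stronger effect of the compound at the concentration tested, a lower number a weaker effect), the measured compounds read as follows:
compound 1 `N#CC1=C(N)N(c2ccc(S(N)(=O)=O)cc2)C2=C(CCCC2)C1c1ccccc1O` gives 100%
compound 2 `COc1ccccc1C1C(C#N)=C(N)N(c2ccc(S(N)(=O)=O)cc2)C2=C1CCCC2` gives 100%
compound 3 `N#CC1=C(N)N(c2ccc(S(N)(=O)=O)cc2)C2=C(CCCC2)C1c1c(O)ccc2ccccc12` gives 50%

Compound 1 and compound 2 differ by methyl in place of hydrogen on an oxygen on an aromatic ring. In this assay this gave no change at the digits printed from compound 1 to compound 2 (within the scatter), although both compounds sit at the top of the scale, so the change could have done little either way without showing. Compound 3 carries a larger group on the same core position: 2-hydroxynaphthalen-1-yl in place of 2-hydroxyphenyl on a saturated ring carbon. That change read a number 50 percentage points lower from compound 1 to compound 3 (beyond the scatter), and against compound 2 it read a number 50 percentage points lower from compound 2 to compound 3 (beyond the scatter). Compound 3 stands lowest of the three measured compounds.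

Compound 4 `COc1ccc2ccccc2c1C1C(C#N)=C(N)N(c2ccc(S(N)(=O)=O)cc2)C2=C1CCCC2` has not yet been measured. It differs from compound 3 by methyl in place of hydrogen on an oxygen on an aromatic ring, which is the same change as from compound 1 to compound 2. On the core of compound 3 the step is expected to be no change at the digits printed from compound 3 to compound 4 (within the scatter), because the earlier pair gave no change at the digits printed from compound 1 to compound 2 (within the scatter); the reservation is that the earlier pair was read at the ceiling. Compound 4 is therefore estimated at 50%, with a range of 30% to 75%.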

Compound 4, a percentage reported as activity, at one concentration (the size of the read-out at that concentration, not a potency): 50%
Estimate against measurement, compound 4: no gap at the digits printed; the measured number falls inside the stated range.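

In this assay, methyl in place of hydrogen on an oxygen on an aromatic ring gave no change at the digits printed from compound 3 to compound 4 (within the scatter), and the two cores read alike for this change: the same change on two cores in this assay, no change at the digits printed (within the scatter) from compound 1 to compound 2 and no change at the digits printed (within the scatter) from compound 3 to compound 4, 0 percentage points apart, within the scatter of two such steps. The new pair carries more weight than the earlier one, since compound 3 at 50% lies well away from the top of the scale, where compound 1 at 100% left the step little room to show. This shows that the change carried over between these two cores, but it rests on two pairs read at a single concentration, so it does not show that potency is unchanged or that the same would hold on any other core in the series.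

The compounds shown carry only hydroxy or methoxy at this place, so it remains open how an ethoxy group, a longer chain on the oxygen or an amine in place of the oxygen would read. On these data alone, it also remains open whether the methyl step stays as flat at other concentrations of the compounds.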